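Trading the fluorine on the cyclopropyl ring for a methyl

The source may hold more compounds than are shown below. What is called first, only, known or untested is meant among the compounds shown, and "the series" means these compounds.

Of the compounds shown here, three share one core and have been measured in an assay on CHO cells for agonist activity at Neuronal acetylcholine receptor; alpha3/alpha6/beta2/beta3 (Homo sapiens), read by FLIPR and calcium flux; on this read-out lower numbers stand for an effect already at smaller amounts and higher numbers for an effect only at larger amounts of compound. Compound 1 `CC(=O)N1CC2CC(C1)N2` gives 750 nM. Compound 2 `O=C(C1CC=CC1)N1CC2CC(C1)N2` gives 1900 nM. Compound 3 `O=C([C@H]1C[C@H]1F)N1CC2CC(C1)N2` gives 62 nM, the lowest of the three numbers: compound 1 sits a good way above it, and compound 2 further still. Going by the values given here, the one step measured so far between neighbours in this set is a 12-fold lower number from compound 1 to compound 3 (1.08 log units; beyond the scatter), so the ring on the carbonyl carbon has clearly mattered.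

Compound 4 `C[C@@H]1C[C@H]1C(=O)N1CC2CC(C1)N2` has not yet been measured in this assay. It differs from compound 3 in one place: 2-methylcyclopropyl in place of 2-fluorocyclopropyl on a carbonyl carbon. Among the compounds with values here, no measured pair shows the exchange of a fluorine for a methyl on this ring, so the earlier step gives only an indirect guide; it shows that the carbonyl substituent can move the number a long way, but not in which direction this particular swap will move it. With the ring itself kept, he expects compound 4 to stay nearer compound 3 than compound 1, estimating 150 nM with a range from 40 nM to 600 nM, which would mean an estimated step of a 2.4-fold higher number from compound 3 to compound 4 (0.38 log units; beyond the scatter).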

Compound 4, half-maximal effective concentration: 51 nM
Beside the measured number, compound 4's estimate is 2.9-fold (0.47 log units) above it, and the stated range covers the measured number.
By their numbers in this assay, from the lowest: compounds 4 and 3 (each within the scatter of the next); then compound 1; then compound 2.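

In this assay the exchange of the fluorine for a methyl on the ring gives a 1.2-fold lower number from compound 3 to compound 4 (0.08 log units; within the scatter) and so leaves the number effectively unchanged, which means that on this carbonyl carbon the 2-fluorocyclopropyl and 2-methylcyclopropyl groups cannot be told apart. The fluorine is therefore not needed for the large gain over the plain methyl, since the methyl-bearing ring also gives a 15-fold lower number from compound 1 to compound 4 (1.17 log units; beyond the scatter) and thus stands well clear of the starting amide. Nothing available explains why the two rings read alike.

Still open, from the compounds shown here alone, is whether an unsubstituted cyclopropyl ring would read the same, or whether a trifluoromethyl or methoxymethyl group on the ring would keep the number this low. Going by these compounds, the other arrangements of the two stereocentres also remain open.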